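A few compounds are considered here, and "the series" means these few. Any claim that something is new, unique, unknown or untested is made for them only; others in the source may bear on it.

Three compounds share a common core and were examined in a functional assay on CHO cells for antagonist activity at sphingosine 1-phosphate receptor 2 (Homo sapiens), read by calcium flux; on this read-out lower numbers stand for stronger inhibition and higher numbers for weaker inhibition. Compound 1 `O=C(O)Cn1nc(CC(=O)Nc2ccc(OC(F)(F)F)c(Cl)c2)c2ccccc2c1=O` gives 389 nM in this assay. Compound 3 `O=C(O)Cn1nc(Cc2nc3cc(F)c(OCC4CC4)cc3[nH]2)c2ccccc2c1=O` gives 18 nM in this assay. Compound 2 `CC(C)(C(=O)O)c1nn(Cc2cn3cc(OCC4CC4)c(Cl)cc3n2)c2ccccc2c1=O` gives 7.7 nM in this assay, the lowest of the three numbers; compound 3 comes nearest, with a number beyond the scatter above it, while compound 1 stands far higher, also beyond the scatter.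

Compound 4 `COC(C(=O)O)c1nn(Cc2cn3cc(OCC4CC4)c(Cl)cc3n2)c2ccccc2c1=O` has not yet been measured. It differs from compound 2 in one place, (carboxy(methoxy)methyl in place of 1-carboxy-1-methylethyl on an aromatic carbon). Going by the values given here, no step between measured compounds matches this change, so its effect must be judged from compound 2 alone; none of the other compounds carries either group.

A modest loss of potency is expected, from compound 2 to compound 4, of roughly a 1.9-fold higher number from compound 2 to compound 4 (0.29 log units; within the scatter), though a result inside the scatter would not surprise. Compound 4 is therefore estimated at 15 nM in this assay, with a likely range from 4 nM to 60 nM.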

Compound 4, half-maximal inhibitory concentration: 23 nM
Estimate against measurement, compound 4: 1.5-fold (0.19 log units) below; low and high end bracket the measured number.
By their numbers in this assay, from the lowest: compound 2; then compounds 3 and 4 (each within the scatter of the next); then compound 1.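

In this assay, placing carboxy(methoxy)methyl instead of 1-carboxy-1-methylethyl on the aromatic carbon next to the ring nitrogen gives a 3.0-fold higher number from compound 2 to compound 4 (0.48 log units; beyond the scatter), so this position is sensitive to the make-up of the group it carries. Both groups hold 6 heavy atoms and 1 hydrogen-bond donor, while the entering group has 3 oxygen rather than 2 and 2 hydrogen-bond acceptors rather than 1, so a match in heavy-atom count does not make the two groups interchangeable here. Nothing in hand explains the shift.

Going by these compounds alone, the single step cannot separate the effect of adding the methoxy from that of removing the two methyl groups, and a 1-carboxyethyl group at this position would help to tell them apart. Going by these compounds, it also remains open whether a tetrazole could stand in for the carboxylic acid here.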